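This account rests on a few compounds, and the source may have more. Where it says the series, first, only, none or still open, it means among the compounds named here.

Measured compounds:
- compound 1, `Clc1ccccc1CSc1nnc(-c2ccncc2)n1-c1ccccc1`: 13900 nM
- compound 2, `Fc1ccc(CSc2nnc(-c3ccncc3)n2-c2ccccc2)c(F)c1`: 11400 nM
- compound 3, `O=C(CSc1nnc(-c2ccncc2)n1-c1ccccc1)N/N=C/c1ccccc1`: 14700 nM

All three share one core and were tested in a functional assay on HCT-116 cells (Homo sapiens) for inhibition, read by MTT assay, with a stated time of 48 h; on this read-out higher numbers stand for weaker inhibition and lower numbers for stronger inhibition. Within the data shown here, compound 1 gives 13900 nM and compound 2 gives 11400 nM; the one step between them, a 1.2-fold lower number from compound 1 to compound 2 (0.09 log units; within the scatter), concerns 2,4-difluorophenyl in place of 2-chlorophenyl on a saturated chain carbon bound to a sulfur. Compound 3 gives 14700 nM, the highest of the three numbers, but its gaps to compound 1 and to compound 2 both lie within the scatter, so the three compounds cannot be ordered on these values.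

Compound 4, `O=C(CSc1nnc(-c2ccncc2)n1-c1ccccc1)N/N=C/c1ccc(O)c(O)c1`, differs from compound 3 in one place: 3,4-dihydroxyphenyl in place of phenyl on a carbon with a double bond to nitrogen. Among the measured compounds shown here, no measured step in this assay touches the ring on the carbon with a double bond to nitrogen; the only step on hand, a 1.2-fold lower number from compound 1 to compound 2 (0.09 log units; within the scatter), sits elsewhere and was itself within the scatter. The data therefore give no ground for expecting a step beyond the scatter in this assay in either direction, and compound 4 is expected to stay close to compound 3, with the step of a 1.2-fold lower number from compound 3 to compound 4 (0.09 log units; within the scatter) as the central guess. The estimate for compound 4 is 12000 nM, in a range from 4000 nM to 36000 nM.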

Compound 4, half-maximal inhibitory concentration: 14700 nM
Compound 4: the middle estimate sits 1.2-fold (0.09 log units) below what was measured; the range from low to high includes it.
By their numbers in this assay, from the lowest: compounds 2, 1, 3 and 4 (each within the scatter of the next).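

In this assay, placing 3,4-dihydroxyphenyl in place of phenyl on a carbon with a double bond to nitrogen gives no change at the digits printed from compound 3 to compound 4 (within the scatter), the first step shown at this position. The entering group has 8 heavy atoms against 6 for phenyl, and 2 hydrogen-bond donors and 2 hydrogen-bond acceptors where phenyl has 0 of each, yet this difference in the group comes with no step beyond the scatter. No measured evidence bears on why the number stays where it does.

As far as these compounds go, it remains open whether a group of another kind on this carbon, such as an amine, a carboxylic acid or a longer chain ending in a morpholine, would move the number beyond the scatter in this assay. Both steps shown, a 1.2-fold lower number from compound 1 to compound 2 (0.09 log units; within the scatter) and the one at this position, stay within the scatter, so neither place has yet been tied to a real change in the number, and the hydroxyl groups of compound 4 have not been looked at one at a time.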